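The source may hold more compounds than are shown below. What is called first, only, known or untested is meant among the compounds shown, and "the series" means these compounds.

Measured compounds in an assay on isolated protein for inhibition of aldehyde dehydrogenase 1A1 (Homo sapiens), read by spectrophotometry, tested at 10 uM; a higher number here means more inhibition at the concentration tested (going by the name of the read-out), a lower number less inhibition:

Compound 1 `Cc1cccc(Cn2c(CN3CCN(C(=O)c4ccc([N+](=O)[O-])cc4)CC3)nc3ccccc32)c1`: 24.3%
Compound 2 `CCC(=O)N1CCN(Cc2nc3ccccc3n2Cc2cccc(C)c2)CC1`: 85.1%

Compound 2 stands highest of the two measured compounds in this assay. Its nearest neighbour is compound 1, and the step of a number 60.8 percentage points higher from compound 1 to compound 2 (beyond the scatter) lies well beyond the scatter. Among the compounds with values here, that step exchanges a 4-nitrophenyl group for an ethyl group on the carbonyl carbon and is the only measured step in the set.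

Compound 3 `CCCC(=O)N1CCN(Cc2nc3ccccc3n2Cc2cccc(C)c2)CC1` is the unmeasured compound. It differs from compound 2 as follows: methyl in place of hydrogen on a saturated chain carbon, two bonds along the chain from a carbonyl carbon.

The measured step from compound 1 to compound 2 does not bear closely on this change: it replaces an aryl group by a short alkyl chain, whereas the step to compound 3 only extends that chain by one carbon. Within the data shown here, no measured pair in this set shows what lengthening a saturated chain at this place does. With nothing to suggest a shift, the step of a number 5.1 percentage points lower from compound 2 to compound 3 (within the scatter) is expected to stay within the scatter, in no particular direction. The estimate for compound 3 in this assay is 80%, within 60% to 95%.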

Compound 3, a percentage reported as inhibition, at one concentration (the size of the read-out at that concentration, not a potency): 79.1%
Compound 3: the middle estimate sits 0.9 percentage points above what was measured, and the stated range covers the measured number.
By their numbers in this assay, from the lowest: compound 1; then compounds 3 and 2 (each within the scatter of the next).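

In this assay, the added methyl on a saturated chain carbon, two bonds along the chain from a carbonyl carbon, gives a number 6 percentage points lower from compound 2 to compound 3 (within the scatter) and so turning ethyl into propyl leaves the read-out where it was, which compound 2 alone could not show. The comparison with the aryl compound gives a number 54.8 percentage points higher from compound 1 to compound 3 (beyond the scatter) and so the large gain over compound 1 no longer rests on ethyl alone: two short alkyl chains on the carbonyl carbon, in compound 2 and compound 3, now stand well clear of 4-nitrophenyl. Nothing available explains why the chain can grow here without a visible effect or why 4-nitrophenyl reads so differently.

The compounds leave open how far this holds, whether a longer chain such as pentyl, a branched one such as isopropyl, or a chain ending in an amine or a carboxylic acid would stay with compound 2 and compound 3. They also leave open whether plain phenyl on the carbonyl carbon would sit with these two or with compound 1.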